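A few compounds are considered here, and "the series" means these few. Any claim that something is new, unique, unknown or untested is made for them only; others in the source may bear on it.

Measured compounds:
- Compound 1, `O=C(O)CNc1cccc(CNc2cc(C(F)(F)F)cc3[nH]ncc23)c1`: in an assay for inhibition of Tryptophan 2,3-dioxygenase (Homo sapiens), with stated times of 10 min and 60 min (on this read-out lower numbers stand for stronger inhibition and higher numbers for weaker inhibition), compound 1 reaches only the assay limit of > 100000 nM.
- Compound 2, `FC(F)(F)c1cccc(CNc2cc(C(F)(F)F)cc3[nH]ncc23)c1`: in this assay compound 2 gives 12200 nM.
- Compound 3, `FC(F)(F)c1cc(NC[C@H]2CCCCN2)c2cn[nH]c2c1`: in this assay compound 3 gives 460 nM.

Among the two numbers that are not limits, compound 3 has the lower one; compound 2 sits well above it, beyond the scatter. Compound 4, `Nc1cccc(CNc2cc(C(F)(F)F)cc3[nH]ncc23)c1`, is not yet measured. It differs from compound 3 by 3-aminophenyl in place of piperidin-2-yl on a saturated chain carbon bound to a nitrogen on an aromatic ring.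

Among the measured compounds shown here, only one measured step is available, and it concerns the two aromatic analogues: an at least 8.1-fold lower number from compound 1 to compound 2 (0.91 log units; beyond the scatter). Compound 1 sits at the limit (the limit of > 100000 nM in this assay, at which 1 of the 3 values shown sits), so this step is a lower bound only. For the measured compounds named here, no step is given between compound 2 and compound 3; what the numbers show is that the aromatic ring of compound 2 comes with a much higher number than the saturated ring of compound 3. Compound 4 carries an aromatic ring again, so a sizeable rise in this assay is expected, roughly a 33-fold higher number from compound 3 to compound 4 (1.51 log units; beyond the scatter). The estimate for compound 4 in this assay is 15000 nM, expected to lie between 3000 nM and 70000 nM.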

Compound 4, half-maximal inhibitory concentration: 2510 nM
Estimate against measurement, compound 4: 6.0-fold (0.78 log units) above, outside the stated range (below it).
By their numbers in this assay, from the lowest: compound 3; then compound 4; then compound 2. At a limit, above all of these: compound 1.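

In this assay, among the compounds shown here, this position tolerates an aromatic ring better than the earlier compounds could show: 3-aminophenyl in place of piperidin-2-yl gives a 5.5-fold higher number from compound 3 to compound 4 (0.74 log units; beyond the scatter). The group carried on that aromatic ring also matters, since amino in place of trifluoromethyl gives a 4.9-fold lower number from compound 2 to compound 4 (0.69 log units; beyond the scatter). Hydrogen in place of carboxymethyl on the nitrogen on the aromatic ring gives an at least 39-fold lower number from compound 1 to compound 4 (1.60 log units; beyond the scatter), but this is only a bound, since the starting value of this step is a limit of the assay: the limit of > 100000 nM in this assay, at which 1 of the 4 values shown sits.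

From the compounds shown here alone, whether a pyrrolidin-2-yl ring or an open-chain amine in place of piperidin-2-yl on the saturated chain carbon would keep the number of compound 3 remains open. Also open, going by these compounds, is how a hydroxyl or a carboxylic acid in place of the amino group would compare with compound 4.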